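Ring Size at the Amine: From Compound 3 to Compound 4

This account rests on a few compounds, and the source may have more. Where it says the series, first, only, none or still open, it means among the compounds named here.

Compound 1 `Cc1nn([C@H](C)c2ccc(Cl)cc2Cl)c2nc(N3CC[C@H](N4CCC[C@H]4CCS(C)(=O)=O)[C@H](C)C3)cnc12` gives 104 nM in a functional assay on cells for antagonist activity at C-C chemokine receptor type 4 (Homo sapiens), read by fluorescence and calcium flux, with stated times of 2.5 s and 45 s; a lower number here means a stronger inhibitor, a higher number a weaker inhibitor.
Compound 2 `Cc1nn([C@H](C)c2ccc(Cl)cc2Cl)c2nc(N3CC[C@H](N4CCCCC4)[C@H](C)C3)cnc12` gives 42 nM in this assay.
Compound 3 `Cc1nn([C@H](C)c2ccc(Cl)cc2Cl)c2nc(N3CC[C@H](N4CCC[C@H]4C(=O)O)[C@H](C)C3)cnc12` gives 670 nM in this assay.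

Compound 3 stands highest of the three numbers. Compound 1 lies nearest to it, as the step of a 6.4-fold higher number from compound 1 to compound 3 (0.81 log units; beyond the scatter) shows, and compound 2 furthest, as the step of a 16-fold higher number from compound 2 to compound 3 (1.20 log units; beyond the scatter) shows. Compound 4 `Cc1nn([C@H](C)c2ccc(Cl)cc2Cl)c2nc(N3CC[C@H](N4CCCCCC4)[C@H](C)C3)cnc12` differs from compound 3 in one place: azepan-1-yl in place of 2-carboxypyrrolidin-1-yl on a saturated ring carbon. The step that bears most on this change is a 16-fold higher number from compound 2 to compound 3 (1.20 log units; beyond the scatter), since azepan-1-yl, like piperidin-1-yl, is a plain saturated ring; the step of a 6.4-fold higher number from compound 1 to compound 3 (0.81 log units; beyond the scatter) points the same way. A large fall in the number is therefore expected in this assay. Compound 4 is expected to give about 55 nM, between 20 nM and 160 nM. The expected step is a 12-fold lower number from compound 3 to compound 4 (1.09 log units; beyond the scatter).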

Compound 4, half-maximal inhibitory concentration: 23 nM
Compound 4: the middle estimate sits 2.4-fold (0.38 log units) above what was measured; low and high end bracket the measured number.
By their numbers in this assay, from the lowest: compounds 4 and 2 (each within the scatter of the next); then compound 1; then compound 3.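

In this assay, azepan-1-yl on this saturated ring carbon cannot be told apart from piperidin-1-yl, with a 1.8-fold lower number from compound 2 to compound 4 (0.26 log units; within the scatter), so enlarging the plain ring to seven members leaves the number unchanged within the scatter. Azepan-1-yl also gives a lower number than either substituted pyrrolidine, with a 29-fold lower number from compound 3 to compound 4 (1.46 log units; beyond the scatter) and a 4.5-fold lower number from compound 1 to compound 4 (0.66 log units; beyond the scatter). No measurement offered here accounts for these differences.

The compounds shown leave open whether an unsubstituted pyrrolidin-1-yl ring or a morpholin-4-yl ring would match the plain rings. They also leave open whether the five-membered ring or its substituent accounts for the higher numbers of compound 1 and compound 3.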